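A few compounds are considered here, and "the series" means these few. Any claim that something is new, unique, unknown or untested is made for them only; others in the source may bear on it.

Working notes on the series, read in a functional assay on HepG2 cells (Homo sapiens) for antiproliferative activity, read by MTT assay, with a stated time of 24 h; a higher number here means a weaker inhibitor, a lower number a stronger inhibitor. Compound 3 `COc1cc(OC)c(-c2coc3cc(OCc4cccc(Br)c4)ccc3c2=O)cc1OC` gives 870 nM, the lowest of the values that are actual numbers. Compound 2 `COc1cc(OC)c(-c2coc3cc(OCc4ccc(C#N)cc4)ccc3c2=O)cc1OC` gives 4230 nM. Compound 1 `COc1cc(OC)c(-c2coc3cc(OCC(=O)c4cccc(C(F)(F)F)c4)ccc3c2=O)cc1OC` reads > 10000 nM, which is a limit of the assay and not a number.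

Compound 4 `COc1cc(OC)c(-c2coc3cc(OCc4cccc(C(F)(F)F)c4)ccc3c2=O)cc1OC` differs from compound 3 in one place: trifluoromethyl in place of bromo on an aromatic carbon, with trifluoromethyl in place of bromo on an aromatic carbon, meta to a large group. For the measured compounds named here, no measured step isolates this exchange. The closest is a 4.9-fold lower number from compound 2 to compound 3 (0.69 log units; beyond the scatter), which also changes the group on the benzyl ring, and it is modest. Compound 1 carries the 3-(trifluoromethyl)phenyl group on a carbonyl, and an at least 11-fold lower number from compound 1 to compound 3 (1.06 log units; beyond the scatter) is large, but it replaces that whole unit and so bears only weakly here.

A small move towards a higher number is therefore expected, no larger than the modest step to compound 3. The expected change is a 1.5-fold higher number from compound 3 to compound 4 (0.17 log units; within the scatter). For compound 4 the estimated value is 1300 nM, with an expected range of 450 nM to 4000 nM.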

Compound 4, half-maximal inhibitory concentration: 610 nM
Compound 4: the middle estimate sits 2.1-fold (0.33 log units) above what was measured, within the range that was stated.
By their numbers in this assay, from the lowest: compounds 4 and 3 (each within the scatter of the next); then compound 2. At a limit, above all of these: compound 1.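

At this place on the aromatic ring, bromo and trifluoromethyl read alike in this assay, with a 1.4-fold lower number from compound 3 to compound 4 (0.15 log units; within the scatter), so one heavy atom can give way to four with no change beyond the scatter. The 3-(trifluoromethyl)phenyl group also stands apart from 4-cyanophenyl, with a 6.9-fold lower number from compound 2 to compound 4 (0.84 log units; beyond the scatter), although that exchange alters both the group and its place on the ring. With 3-(trifluoromethyl)phenyl on both sides, an at least 16-fold lower number from compound 1 to compound 4 (1.21 log units; beyond the scatter) isolates the carbonyl on the chain, but the size of this step is only a bound, compound 1 being at a limit of the assay: the limit of > 10000 nM in this assay, at which 1 of the 4 values shown sits.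

The compounds shown leave open whether an amine or a carboxylic acid on this aromatic carbon would read like bromo and trifluoromethyl. They also leave open how a nitrile would read here, and how a longer chain would read in place of the single saturated chain carbon.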